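Ring size on the carbonyl substituent: cyclopropyl to cyclobutyl

The source may hold more compounds than are shown below. What is called first, only, known or untested is meant among the compounds shown, and "the series" means these compounds.

Among the measured compounds shown here, compound 2 `CC1(C)SC(c2cc(Cl)ccc2N)=NN1C(=O)C1CC1` stands highest of the two numbers so far: in an assay on isolated protein for inhibition of Nitric oxide synthase, inducible (Homo sapiens), read by scintillation counting, with a stated time of 30 min, tested at 50 uM (a higher number here means more inhibition at the concentration tested (going by the name of the read-out), a lower number less inhibition), compound 2 gives 23.2%, while compound 1 `CCC(=O)N1N=C(c2cc(Cl)ccc2N)SC1(C)C` gives 1.07%. For the measured compounds named here, the single measured step, a number 22.1 percentage points higher from compound 1 to compound 2 (beyond the scatter), is the only one that bears on the next change, which enlarges the same ring. Compound 3 `CC1(C)SC(c2cc(Cl)ccc2N)=NN1C(=O)C1CCC1` differs from compound 2 by cyclobutyl in place of cyclopropyl on a carbonyl carbon. Because a number 22.1 percentage points higher from compound 1 to compound 2 (beyond the scatter) was modest, a small rise or no step beyond the scatter is expected, a number 4.8 percentage points higher from compound 2 to compound 3 (within the scatter). Compound 3 is expected to give 28%, within 5% to 55%.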

Compound 3, a percentage reported as inhibition, at one concentration (the size of the read-out at that concentration, not a potency): -4.65%
For compound 3 the middle estimate is 32.7 percentage points above the measured one, and the stated range ends above it.
By their numbers in this assay, from the lowest: compounds 3 and 1 (each within the scatter of the next); then compound 2.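

In this assay, the gain from ethyl to cyclopropyl does not extend to the next ring size: cyclobutyl in place of cyclopropyl on a carbonyl carbon gives a number 27.9 percentage points lower from compound 2 to compound 3 (beyond the scatter). Cyclobutyl in place of ethyl gives a number 5.7 percentage points lower from compound 1 to compound 3 (within the scatter), so among these three substituents only cyclopropyl stands apart. Nothing available accounts for this difference.

As far as these compounds go, whether cyclopentyl, a longer chain or an amine on the same carbonyl carbon would exceed compound 2 stays open. Potency also stays open, since each number comes from a single concentration.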